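Extending the Chain from Compound 2 to Compound 4

This account rests on a few compounds, and the source may have more. Where it says the series, first, only, none or still open, it means among the compounds named here.

In a functional assay (brain) for inhibition, with Rattus norvegicus as the target (on this read-out higher numbers stand for weaker inhibition and lower numbers for stronger inhibition), compound 1 (`CCCCCCCCCCCCOC1=C(O)OC(C(O)CO)C1=O`) gives 54000 nM, compound 2 (`CCCCCCCCCCCCCOC1=C(O)OC(C(O)CO)C1=O`) gives 7400 nM and compound 3 (`CCCCCCCCCCCCCCOC1=C(O)OC(C(O)CO)C1=O`) gives 7400 nM. Compound 2 therefore stands level with compound 3, and both sit under compound 1.

Compound 4 (`CCCCCCCCCCCCCCCCCOC1=C(O)OC(C(O)CO)C1=O`) keeps the shared core and differs from compound 2 only in its chain: butyl in place of hydrogen on a saturated chain carbon, ten or more bonds along the chain from an oxygen on an unsaturated carbon. This is butyl in place of hydrogen on a saturated chain carbon, ten or more bonds along the chain from an oxygen on an unsaturated carbon.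

For the measured compounds named here, three measured steps bear on this change. Going by the values given here, the chain changes gave a 7.3-fold lower number from compound 1 to compound 2 (0.86 log units; beyond the scatter) and a 7.3-fold lower number from compound 1 to compound 3 (0.86 log units; beyond the scatter), yet the only step starting from compound 2 gave no change at the digits printed from compound 2 to compound 3 (within the scatter). Among the compounds with values here, no measured compound has a chain as long as that of compound 4, so the further course is unknown, and the flat last step carries the most weight.

No step beyond the scatter is expected, and the estimate is a 1.1-fold lower number from compound 2 to compound 4 (0.02 log units; within the scatter). For compound 4 the expected value is 7000 nM, with an estimated range of 2500 nM to 22000 nM.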

Compound 4, half-maximal inhibitory concentration: 11000 nM
Compound 4: the middle estimate sits 1.6-fold (0.20 log units) below what was measured; measured number inside the range.
By their numbers in this assay, from the lowest: compounds 2, 3 and 4 (each within the scatter of the next); then compound 1.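

Adding butyl in place of hydrogen on this saturated chain carbon extends the flat stretch in this assay: the result is a 1.5-fold higher number from compound 2 to compound 4 (0.17 log units; within the scatter), and propyl in place of hydrogen gives a 1.5-fold higher number from compound 3 to compound 4 (0.17 log units; within the scatter), so compounds 2, 3 and 4 cannot be told apart in this read-out. The separation from the shortest chain persists, with pentyl in place of hydrogen giving a 4.9-fold lower number from compound 1 to compound 4 (0.69 log units; beyond the scatter), so the extra carbons of compound 4 neither add to nor lose the difference that compounds 2 and 3 already showed from compound 1. Nothing available explains why the numbers level off along this chain.

From the compounds shown here alone, whether a still longer chain would stay level with these three compounds or move beyond the scatter remains open. So does how an amine or a carboxylic acid on the chain would read in this assay.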